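The source may report more compounds than this note shows. Statements on the series, on what has been measured and on what is new or still open speak of the compounds shown alone.

Compound 1 `CC1Cc2c(sc(NC(=O)c3ccccc3O)c2C(N)=O)C(C)O1` gives 4 nM in an assay on cells for positive allosteric modulation of Cystic fibrosis transmembrane conductance regulator variant F508del (Homo sapiens), with stated times of 10 min and 7 s, in the presence of a further agent that is not named here; a lower number here means that less compound is needed, a higher number that more compound is needed for the effect.
Compound 2 `CC1(C)Cc2c(sc(NC(=O)c3ccccc3O)c2C(N)=O)C(C)(C)O1` gives 4 nM.
Compound 3 `CC1(C)Cc2c(sc(NC(=O)c3nnc[nH]3)c2C(N)=O)C(C)(C)O1` gives 467 nM.

Compound 3 stands highest of the three numbers; its nearest neighbour is compound 1, and compound 2 lies at the same distance. Compound 4 `CC1(C)Cc2c(sc(NC(=O)c3ccn[nH]3)c2C(N)=O)C(C)(C)O1` differs from compound 3 in that (1H-pyrazol-5-yl in place of 4H-1,2,4-triazol-3-yl on a carbonyl carbon). Among the measured compounds shown here, no measured step covers this exchange directly. For the measured compounds named here, the only step that touches the group on the carbonyl carbon is a 120-fold higher number from compound 2 to compound 3 (2.07 log units; beyond the scatter), a large move away from the hydroxyphenyl. Given the step of a 120-fold higher number from compound 2 to compound 3 (2.07 log units; beyond the scatter), compound 4 is expected to remain far from compound 2 and near compound 3, with a step of a 1.6-fold lower number from compound 3 to compound 4 (0.19 log units; within the scatter) that need not exceed the scatter. Compound 4 is estimated at 300 nM, in the range 60 nM to 1500 nM.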

Compound 4, half-maximal effective concentration: 3 nM
Beside the measured number, compound 4's estimate is 100-fold (2.00 log units) above it; measured number outside the range, below it.
By their numbers in this assay, from the lowest: compounds 4, 1 and 2 (each within the scatter of the next); then compound 3.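

In this assay the group on the carbonyl carbon is shown to tolerate a five-membered aromatic ring, as there is a 160-fold lower number from compound 3 to compound 4 (2.19 log units; beyond the scatter) when 1H-pyrazol-5-yl replaces 4H-1,2,4-triazol-3-yl. The loss seen with the triazole is therefore not shared by this other ring, and the 2-hydroxyphenyl is not required, since a 1.3-fold lower number from compound 2 to compound 4 (0.12 log units; within the scatter) stays within the scatter. Nothing available here explains the difference between the two rings. Still open, on these data alone, is whether 1H-pyrazol-5-yl holds this number on the core of compound 1, and whether a carboxylic acid or an amine on that ring would do the same.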